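The source may report more compounds than this note shows. Statements on the series, on what has been measured and on what is new or still open speak of the compounds shown alone.

Compound 1 `CCOC(=O)/C=C1/C(=O)Nc2ccccc21` gives 89.3% in a functional assay on HCT-116 cells (Homo sapiens) for inhibition, read by CCK-8 assay, with a stated time of 72 h, tested at 20 uM; a lower number here means less inhibition of growth, a higher number more inhibition of growth at the concentration tested.
Compound 2 `CC(C)(C)OC(=O)/C=C1/C(=O)Nc2ccccc21` gives 89.5% in this assay.

On these two numbers compound 2 stands as the higher one, but only by a number 0.2 percentage points higher from compound 1 to compound 2 (within the scatter), a step that lies within the scatter, so the two compounds cannot be told apart. For the measured compounds named here, that single step, the exchange of tert-butyl for ethyl on the ester oxygen, is the only measured comparison available, and it leaves the inhibition unchanged.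

Compound 3 `Cc1ccc2c(c1)/C(=C\C(=O)OC(C)(C)C)C(=O)N2` differs from compound 2 by methyl in place of hydrogen on an aromatic carbon. Going by the values given here, no measured step touches that aromatic ring, so the data give no direction for this change; the one known step on the ester end showed nothing beyond the scatter. The expectation for compound 3 is therefore a step of a number 2.5 percentage points lower from compound 2 to compound 3 (within the scatter) in this assay, nothing beyond the scatter. Compound 3 is estimated at 87%, with a range from 72% to 95%.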

Compound 3, percent growth inhibition at one concentration: 89.4%
Compound 3: middle estimate off by 2.4 percentage points, on the low side; the range from low to high includes it.
By their numbers in this assay, from the lowest: compounds 1, 3 and 2 (each within the scatter of the next).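

For the compounds shown here, on the aromatic ring, where no step had been measured before, methyl in place of hydrogen gives a number 0.1 percentage points lower from compound 2 to compound 3 (within the scatter) in this assay. So at this carbon, meta to a fused ring and para to a fused ring, this one added carbon leaves the growth inhibition indistinguishable at the concentration tested, just as the exchange on the ester oxygen did. Nothing measured here offers an explanation for this.

The compounds shown leave open whether an amine or a longer chain such as butyl on this carbon, or a carboxylic acid in place of the ester, would carry the number beyond the scatter. They also leave open whether compounds that match at this single concentration would still match at lower concentrations.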